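A Third Methoxy Group Added to Compound 3

The source may report more compounds than this note shows. Statements on the series, on what has been measured and on what is new or still open speak of the compounds shown alone.

Of the compounds shown here, three sharing a bromoacrylamide group have been measured in a functional assay on FM3A cells (Mus musculus) for antiproliferative activity, with a stated time of 48 h; a lower number here means a stronger inhibitor, a higher number a weaker inhibitor. Compound 1, `C=C(Br)C(=O)Nc1ccc(/C=C/C(=O)c2ccccc2)cc1`, gives 3900 nM. Compound 2, `C=C(Br)C(=O)Nc1ccc(/C=C/C(=O)c2cccc(OC)c2)cc1`, carries one change, (methoxy in place of hydrogen on an aromatic carbon), and gives 2700 nM; the step of a 1.4-fold lower number from compound 1 to compound 2 (0.16 log units; within the scatter) is therefore small. Compound 3, `C=C(Br)C(=O)Nc1ccc(C(=O)/C=C/c2ccc(OC)cc2OC)cc1`, has a core that differs from that of compound 1 in a way that is not broken down here, and in this assay compound 3 gives 1200 nM, the lowest of the three numbers, with both other compounds standing beyond the scatter above it.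

Compound 4, `C=C(Br)C(=O)Nc1ccc(C(=O)/C=C/c2ccc(OC)c(OC)c2OC)cc1`, is the next compound and has not yet been measured. It differs from compound 3 by methoxy in place of hydrogen on an aromatic carbon. For the measured compounds named here, this is the same kind of change as the one from compound 1 to compound 2, but not the same: in compound 2 the entering methoxy sits meta to a large group, whereas in compound 4 it also sits ortho to two methoxy groups.

Since the earlier step, a 1.4-fold lower number from compound 1 to compound 2 (0.16 log units; within the scatter), stayed within the scatter, a similarly small step is expected here, a 1.2-fold lower number from compound 3 to compound 4 (0.08 log units; within the scatter), though the different surroundings of the new methoxy leave real uncertainty. Compound 4 is therefore estimated at 1000 nM in this assay, with a plausible range from 400 nM to 2500 nM, pending the actual measurement.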

Compound 4, half-maximal inhibitory concentration: 530 nM
Compound 4: the middle estimate sits 1.9-fold (0.28 log units) above what was measured; the range from low to high includes it.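

Adding the third methoxy group gives a 2.3-fold lower number from compound 3 to compound 4 (0.35 log units; beyond the scatter) in this assay, so this step is modest but, unlike the earlier step, it stands clear of the usual variation between repeated measurements. Even so, when the same change is compared on the two cores, the gap between the two steps is too small to count as a real difference: the same change on two cores in this assay, a 1.4-fold lower number (0.16 log units; within the scatter) from compound 1 to compound 2 and a 2.3-fold lower number (0.35 log units; beyond the scatter) from compound 3 to compound 4, 1.6-fold (0.20 log units) apart, within the scatter of two such steps. The two steps are therefore compatible with the change having a similar effect on the core of compound 1 and the core of compound 3, but two pairs do not establish a general rule for this series, do not show that the step is truly larger on the core of compound 3, and do not explain why the number is lower for compound 4.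

The compounds shown leave open whether a hydroxyl, an amine or a longer ethoxy chain in this same place on the ring would give a step of similar size. They also leave open how the methoxy change would behave if the bromoacrylamide group gave way to a plain acrylamide.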